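The source may hold more compounds than are shown below. What is called first, only, known or untested is meant among the compounds shown, and "the series" means these compounds.

Working notes on the series. The shared core carries a benzylamide whose aryl group varies; compound 1 `COc1ccc(CNC(=O)c2nc(-c3ccc(F)cc3)n(CC[C@@H](O)C[C@@H](O)CC(=O)O)c2C2CC2)cc1F` bears 3-fluoro-4-methoxyphenyl, compound 2 `Cc1ccc(CNC(=O)c2nc(-c3ccc(F)cc3)n(CC[C@@H](O)C[C@@H](O)CC(=O)O)c2C2CC2)cc1` 4-methylphenyl, and compound 3 `O=C(O)C[C@H](O)C[C@H](O)CCn1c(-c2ccc(F)cc2)nc(C(=O)NCc2cccc(F)c2)c1C1CC1` 3-fluorophenyl. In a functional assay on L6 cells (Rattus norvegicus) for inhibition, read by scintillation counting, with a stated time of 3 h (a lower number here means a stronger inhibitor, a higher number a weaker inhibitor), compound 1 gives 890 nM, compound 2 gives 178 nM, and compound 3 gives 444 nM. Compound 3 thus stands second highest of the three numbers: its nearest neighbour is compound 1, a 2.0-fold lower number from compound 1 to compound 3 (0.30 log units; within the scatter), while its furthest is compound 2, a 2.5-fold higher number from compound 2 to compound 3 (0.40 log units; beyond the scatter). Within the data shown here, the larger aryl swap a 5.0-fold lower number from compound 1 to compound 2 (0.70 log units; beyond the scatter) is the only step beyond the scatter that changes more than one substituent.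

Compound 4 `COc1cccc(CNC(=O)c2nc(-c3ccc(F)cc3)n(CC[C@@H](O)C[C@@H](O)CC(=O)O)c2C2CC2)c1` differs from compound 3 by methoxy in place of fluoro on an aromatic carbon, the group sitting on an aromatic carbon of a six-membered aromatic ring of carbon only, meta to a large group. Among the measured compounds shown here, the step that bears most directly on it is the removal of methoxy from compound 1 to compound 3, a 2.0-fold lower number from compound 1 to compound 3 (0.30 log units; within the scatter), which stayed within the scatter; no measured pair exchanges fluoro for methoxy at this position. A step of about the same size, if any, is therefore expected in the opposite direction in this assay, a 1.5-fold higher number from compound 3 to compound 4 (0.17 log units; within the scatter). For compound 4 the expected value is 650 nM, with a range from 250 nM to 1700 nM.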

Compound 4, half-maximal inhibitory concentration: 538 nM
Beside the measured number, compound 4's estimate is 1.2-fold (0.08 log units) above it, and the stated range covers the measured number.
By their numbers in this assay, from the lowest: compound 2; then compounds 3, 4 and 1 (each within the scatter of the next).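

In this assay, methoxy in place of fluoro on this aromatic carbon, meta to a large group, gives a step within the scatter (a 1.2-fold higher number from compound 3 to compound 4 (0.08 log units; within the scatter)), so this position does not separate the two groups, even though methoxy brings one more heavy atom and a hydrogen-bond acceptor. The step from the disubstituted aryl group to 3-methoxyphenyl also stays within the scatter (a 1.7-fold lower number from compound 1 to compound 4 (0.22 log units; within the scatter)), while the step from 4-methylphenyl to 3-methoxyphenyl lies beyond it (a 3.0-fold higher number from compound 2 to compound 4 (0.48 log units; beyond the scatter)), which leaves compound 2 the strongest inhibitor of the four, with its steps to compound 1, compound 3 and compound 4 all printed as beyond the scatter. No supporting measurement is available to explain these steps.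

Among these compounds, the series does not separate the identity of the 4-methylphenyl group from the placement of its substituent, since no compound carries the same methyl group at the position held by fluoro or methoxy. It also leaves open whether this aromatic carbon stays as undiscriminating with a hydroxyl, an amine or a carboxylic acid in place of fluoro.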